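A few compounds are considered here, and "the series" means these few. Any claim that something is new, unique, unknown or untested is made for them only; others in the source may bear on it.

The account follows a functional assay on SV5A8 cells (Homo sapiens) for cytotoxicity (a higher number here means a weaker inhibitor, a lower number a stronger inhibitor), from compound 3, `Cc1ccc2c(NCc3ccc(NC(=O)C4CCN(Cc5ccccc5)CC4)cc3)nc(N3CCC3)nc2c1`, to compound 4, `CCN1CCN(c2nc(NCc3ccc(NC(=O)C4CCN(Cc5ccccc5)CC4)cc3)c3ccc(C)cc3n2)CC1`. In this assay compound 3 gives only a limit, > 8500 nM. Compound 1, `Cc1ccc2c(NCc3ccc(NC(=O)C4CCN(Cc5ccccc5)CC4)cc3)nc(N3CCCCCC3)nc2c1`, likewise gives only a limit in this assay, > 6880 nM. Compound 2, `Cc1ccc2c(NCc3ccc(NC(=O)C4CCN(Cc5ccccc5)CC4)cc3)nc(N3CCN[C@@H](C)C3)nc2c1`, also gives only a limit in this assay, > 8860 nM. All three values sit at limits, as the limit of > 6880 nM in this assay, at which 1 of the 3 values shown sits, the limit of > 8500 nM in this assay, at which 1 of the 3 values shown sits, and the limit of > 8860 nM in this assay, at which 1 of the 3 values shown sits, show, so compound 3 cannot be placed relative to the others on the numbers shown. The change to compound 4 is 4-ethylpiperazin-1-yl in place of azetidin-1-yl on an aromatic carbon. Within the data shown here, two measured steps concern the same place: a step that the two limits leave unreadable from compound 1 to compound 3 and a step that the two limits leave unreadable from compound 2 to compound 3. Neither has a readable size, so no step beyond the scatter can be foreseen in either direction for this assay, and a further limit is the likeliest outcome. In this assay the expected step is a step that the limit leaves unreadable from compound 3 to compound 4. For compound 4 the estimated value in this assay is 10000 nM, with a range from 3000 nM to 30000 nM.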

Compound 4, half-maximal inhibitory concentration: > 13000 nM
Compound 4: a limit, no number; the forecaster's own chance of this, stated with the estimate: 80%; at least 1.3-fold (0.11 log units) between middle value and limit.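

Among these compounds, compound 4 gives only a limit in this assay, as do compound 1, compound 2 and compound 3, so no step between compound 4 and any of them can be read. The compounds shown leave open how these four groups rank in this assay.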